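Piperidine in place of the bicyclic alcohol on compound 1

This account rests on a few compounds, and the source may have more. Where it says the series, first, only, none or still open, it means among the compounds named here.

Compound 1 `Cn1nc(-c2ccc(OCC34CCC(O)(CC3)CC4)c(F)c2)c2cnc(N)nc21` gives 5300 nM in an assay on tissue (PBMC cells) for antagonist activity at Toll-like receptor 9 (Homo sapiens) (on this read-out lower numbers stand for stronger inhibition and higher numbers for weaker inhibition), the highest of the three numbers measured. Compound 2 `Cc1cc(-c2nn(C)c3nc(N)ncc23)cnc1OCC12CCC(N)(CC1)CC2` gives 3300 nM in this assay, a number within the scatter of compound 1. Among the measured compounds shown here, compound 3 `Cc1cc(-c2ccnc3[nH]ncc23)cnc1OCC12CCC(N)(CC1)CC2` gives 1000 nM in this assay, a number beyond the scatter from compound 1; compounds 2 and 3 differ from compound 1 in more than one place, so no single step is computed from them.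

Compound 4 `Cn1nc(-c2ccc(OCC3CCNCC3)c(F)c2)c2cnc(N)nc21` is not yet measured. Compound 4 differs from compound 1 by a group of 6 heavy atoms (5 carbon, 1 nitrogen; one six-membered non-aromatic ring with 1 hetero atom) in place of a group of 9 heavy atoms (8 carbon, 1 oxygen; 2 six-membered non-aromatic rings of carbon only), on a saturated chain carbon bound to an oxygen on an aromatic ring. For the measured compounds named here, no measured pair shows this exchange, so the size of the step is uncertain; the expectation is a moderate move towards a lower number, of a size that may or may not exceed the scatter. Compound 4 is expected to give 3000 nM in this assay, within a range from 1000 nM to 9000 nM. The step from compound 1 to compound 4 expected on this basis is a 1.8-fold lower number from compound 1 to compound 4 (0.25 log units; within the scatter).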

Compound 4, half-maximal inhibitory concentration: 3400 nM
For compound 4 the middle estimate is 1.1-fold (0.05 log units) below the measured one, and the stated range covers the measured number.
By their numbers in this assay, from the lowest: compound 3; then compounds 2, 4 and 1 (each within the scatter of the next).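

In this assay the series now has its first comparison across a single place, a 1.6-fold lower number from compound 1 to compound 4 (0.19 log units; within the scatter). On a saturated chain carbon bound to an oxygen on an aromatic ring, piperidin-4-yl, with 6 heavy atoms and one ring, takes the place of a group of 9 heavy atoms and 2 rings with no change that can be told from the scatter, so on this core and in this one pair the number does not register the exchange. No measurement at hand gives a reason for this result.

On these data alone, whether a 1-methylpiperidin-4-yl group, a morpholine ring or a carboxylic acid at the same place would move the number beyond the scatter stays open. As far as these compounds go, whether piperidin-4-yl behaves the same way on the cores of compound 2 and compound 3 also stays open.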